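A few compounds are considered here, and "the series" means these few. Any claim that something is new, unique, unknown or untested is made for them only; others in the source may bear on it.

Compound 1 `CC(C)(C)Sc1c(CC(C)(C)C(=O)O)n(Cc2ccc(Cl)cc2)c2ccc(OCc3cc4ccccc4cn3)cc12`: 3 nM
Compound 2 `CC(C)(C)Sc1c(CC(C)(C)C(=O)O)n(Cc2ccc(Cl)cc2)c2ccc(OCc3nc4ccccc4o3)cc12`: < 7 nM

For the measured compounds named here, in a functional assay for inhibition, with Homo sapiens as the target (on this read-out higher numbers stand for weaker inhibition and lower numbers for stronger inhibition), compound 1 gives 3 nM, the only plain number among the two results. For compound 2 the result in this assay is a limit of the measurement, < 7 nM, rather than a number. The size of a step that the limit leaves unreadable from compound 1 to compound 2 therefore cannot be read, because of the limit of < 7 nM in this assay, at which 1 of the 2 values shown sits. Compound 3 `CC(C)(C)Sc1c(CC(C)(C)C(=O)O)n(Cc2ccc(Cl)cc2)c2ccc(OCc3cnccn3)cc12` differs from compound 1 by pyrazin-2-yl in place of isoquinolin-3-yl on a saturated chain carbon bound to an oxygen on an aromatic ring. Going by the values given here, no measured step bears directly on this change, so the expectation rests on the structural change alone: a modest weakening of inhibition is expected, a 2.7-fold higher number from compound 1 to compound 3 (0.43 log units; beyond the scatter). Compound 3 is accordingly estimated at 8 nM in this assay, within a range of 2 nM to 30 nM.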

Compound 3, half-maximal inhibitory concentration: 4 nM
For compound 3 the middle estimate is 2.0-fold (0.30 log units) above the measured one; the range from low to high includes it.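

In this assay, pyrazin-2-yl in place of isoquinolin-3-yl gives a 1.3-fold higher number from compound 1 to compound 3 (0.12 log units; within the scatter). On the saturated chain carbon bound to an oxygen on an aromatic ring, the group can therefore shrink from 10 heavy atoms to 6 and lose its six-membered aromatic ring of carbon only, with no change beyond the scatter in this pair. The steps to and from compound 2 cannot be read: the limit of < 7 nM in this assay, at which 1 of the 3 values shown sits.

From the compounds shown here alone, it remains open whether this place needs an aromatic ring at all. A cyclohexyl or morpholine ring here would test that.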